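Replacing the benzylamide of compound 3 with a free acid

The compounds below may be only part of what the source reports. "The series", "measured", "known", "first", "only" and "open" are said of these compounds alone.

Compound 1 `C=CC1=C(C(=O)NCC(C)C)C(c2ccc(Cl)c(Cl)c2)OC1` gives in a functional assay on QGY7701 cells (Homo sapiens) for cytotoxicity, read by MTT assay, with a stated time of 24 h (a higher number here means a weaker inhibitor, a lower number a stronger inhibitor), a reading that is a limit of the assay, > 100000 nM.
Compound 2 `C=CC1=C(C(=O)Nc2ccccc2)C(c2ccc(Cl)c(Cl)c2)OC1` gives in this assay a reading that is a limit of the assay, > 100000 nM.
Compound 3 `C=CC1=C(C(=O)NCc2ccccc2)C(c2ccc(Cl)c(Cl)c2)OC1` gives in this assay a reading that is a limit of the assay, > 100000 nM.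

Compound 3 therefore stands at the assay limit, not at a measured number. Its two neighbours share the same fate, which is why the steps a step that the two limits leave unreadable from compound 1 to compound 2, a step that the two limits leave unreadable from compound 1 to compound 3 and a step that the two limits leave unreadable from compound 2 to compound 3 cannot be read: all three readings sit at the limit of > 100000 nM in this assay, at which 3 of the 3 values shown sit, so no direction or size can be drawn from them.

The next compound, compound 4 `C=CC1=C(C(=O)O)C(c2ccc(Cl)c(Cl)c2)OC1`, changes the amide side of the shared core: hydroxy in place of benzylamino on a carbonyl carbon. Among the measured compounds shown here, no measured step touches this kind of change, and none of the measured steps gives a readable size, so the expectation for compound 4 rests only on three compounds that all failed to reach a number in this assay. The step from compound 3 to compound 4 is expected to be a step that the limit leaves unreadable from compound 3 to compound 4, meaning compound 4 is most likely to return another limit. Compound 4 is estimated at 150000 nM in this assay, with a range from 50000 nM to 500000 nM.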

Compound 4, half-maximal inhibitory concentration: > 100000 nM
Compound 4 was reported as a limit (the forecaster's own chance of this, stated with the estimate: 85%); the middle value is on the limit's open side.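

In this assay compound 4 gives > 100000 nM, which is a limit and not a number. The steps from compound 1, compound 2 and compound 3 to compound 4 cannot be read because all four readings stop at the same limit: the limit of > 100000 nM in this assay, at which 4 of the 4 values shown sit.

The compounds shown leave open whether any group on this carbonyl carbon can bring the shared core to a measurable value.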